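The compounds below may be only part of what the source reports. "The series", "measured", "known", "first", "only" and "open" are said of these compounds alone.

The measured compounds and their results in this cytotoxicity read-out:

compound 1 `Cn1c(-c2ccc(NC(=O)CSc3nc4cc(Cl)ccc4o3)cc2)nc(-c2ccccc2)c1-c1ccccc1` gives 17.4%
compound 2 `Cn1cnnc1SCC(=O)Nc1ccc(-c2nc(-c3ccccc3)c(-c3ccccc3)n2C)cc1` gives 40.8%
compound 3 `CCN1CCN(CC(=O)Nc2ccc(-c3nc(-c4ccccc4)c(-c4ccccc4)n3C)cc2)CC1` gives 13.9%

All three numbers come from a functional assay on HT-29 cells (Homo sapiens) for cytotoxicity, read by MTT assay, with a stated time of 24 h, tested at 1.6 ug/mL; on this read-out lower numbers stand for a weaker effect and higher numbers for a stronger effect at the one concentration tested. Among them compound 1 stands second highest; compound 3 lies nearest to it, and compound 2 lies furthest, with a number 23.4 percentage points higher from compound 1 to compound 2 (beyond the scatter). Compound 4 `Cn1c(-c2ccc(NC(=O)CN3CCN(c4ccccc4)CC3)cc2)nc(-c2ccccc2)c1-c1ccccc1` is the compound still to be measured. It differs from compound 1 as follows: 4-phenylpiperazin-1-yl in place of (5-chloro-1,3-benzoxazol-2-yl)sulfanyl on a saturated chain carbon bound to a carbonyl carbon.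

The step that bears most directly on this change is a number 3.5 percentage points lower from compound 1 to compound 3 (within the scatter), where a piperazinyl group likewise took the place of the sulfanyl group at the same saturated chain carbon, and that step stayed within the scatter. The step of a number 26.9 percentage points lower from compound 2 to compound 3 (beyond the scatter) also ends at a piperazinyl group but begins from a different sulfanyl group, so it speaks less directly to compound 4. On this basis no step beyond the scatter is expected from compound 1 to compound 4 in this assay, that is a number 1.4 percentage points lower from compound 1 to compound 4 (within the scatter). Compound 4 is therefore estimated at 16%, with a range from 5% to 30%.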

Compound 4, a percentage reported as activity, at one concentration (the size of the read-out at that concentration, not a potency): 26%
Estimate against measurement, compound 4: 10 percentage points below, within the range that was stated.
By their numbers in this assay, from the lowest: compounds 3, 1 and 4 (each within the scatter of the next, the first and the last beyond it); then compound 2.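

Within the piperazine pair, the group on the ring nitrogen counts in this assay: phenyl in place of ethyl gives a number 12.1 percentage points higher from compound 3 to compound 4 (beyond the scatter) and is the first change shown at that nitrogen. Putting 4-phenylpiperazin-1-yl on the saturated chain carbon gives a number 8.6 percentage points higher from compound 1 to compound 4 (within the scatter) when it replaces (5-chloro-1,3-benzoxazol-2-yl)sulfanyl, but a number 14.8 percentage points lower from compound 2 to compound 4 (beyond the scatter) when it replaces (4-methyl-4H-1,2,4-triazol-3-yl)sulfanyl, so the phenyl group does not close the gap to compound 2. Nothing available explains these differences.

Going by these compounds, it remains open whether a benzyl group or a methyl group on that ring nitrogen would fall with compound 3 or with compound 4. On these data alone, it is also open whether a morpholin-4-yl group on the chain carbon would behave like either piperazine.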